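This account rests on a few compounds, and the source may have more. Where it says the series, first, only, none or still open, it means among the compounds named here.

Working notes on the series. In a functional assay on SF-268 cells (Homo sapiens) for inhibition, with a stated time of 48 h (a higher number here means a weaker inhibitor of growth, a lower number a stronger inhibitor of growth), compound 1 (`N#Cc1cnn(-c2ccc(C(=O)O)cc2)c1N`) gives "not determined" (no result reported) as its entry. Compound 3 (`CC(=O)OC[C@H]1O[C@@H](Nc2c(C#N)cnn2-c2ccc(C(=O)O)cc2)[C@H](OC(C)=O)[C@@H](OC(C)=O)[C@@H]1OC(C)=O`) likewise gives "not determined" (no result reported) as its entry. Compound 2 (`COC(=O)CNC(=O)c1ccc(-n2ncc3c(N)ncnc32)cc1`) gives > 150000 nM as its entry, which is a limit and not a number. Compound 2 therefore has a position of one kind only (the limit of > 150000 nM in this assay, at which 1 of the 3 values shown sits). Among the measured compounds shown here, the series offers no measured step between compounds, so no size of change can be read from the data.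

Compound 4 (`COc1ccc(-n2ncc3c(N)ncnc32)cc1`) keeps the shared core of compound 2 and differs in one place (methoxy in place of ((methoxycarbonyl)methyl)carbamoyl on an aromatic carbon). It carries methoxy in place of ((methoxycarbonyl)methyl)carbamoyl on an aromatic carbon of a six-membered aromatic ring of carbon only, para to a large group.

For the measured compounds named here, the only anchor is compound 2 at > 150000 nM as a limit, and a number for compound 4 can only be expected on the stronger side of it. The expected move is an at least 2.5-fold lower number from compound 2 to compound 4 (0.39 log units; beyond the scatter) in this assay and is judged modest, towards stronger inhibition of growth. A further limit rather than a number remains a real possibility. Compound 4 is estimated at 60000 nM with an expected range from 15000 nM to 150000 nM for a measured number.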

Compound 4, concentration for 50% growth inhibition: > 150000 nM
Compound 4: a limit, no number (the forecaster's own chance of this, stated with the estimate: 45%); middle value at least 2.5-fold (0.39 log units) away from the limit.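

In this assay compound 4 gives > 150000 nM, a limit and not a number. Among the compounds shown here, compound 2 also stands at a limit, so no step between compound 2 and compound 4 can be read: the limit of > 150000 nM in this assay, at which 2 of the 4 values shown sit. Left open is how far either compound lies from its limit, and whether any group on that aromatic carbon yields a measured number in this assay.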